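Inverting the chain stereocentre of compound 2

A few compounds are considered here, and "the series" means these few. Any claim that something is new, unique, unknown or untested is made for them only; others in the source may bear on it.

- compound 1 `C[C@@H](N/C(=C\[N+](=O)[O-])Nc1cccnc1)C(C)(C)C`: 10 nM; 1000 nM (2 entries)
- compound 2 `COc1cncc(N/C(=C/[N+](=O)[O-])N[C@H](C)C(C)(C)C)c1`: 1580 nM
- compound 3 `COc1cncc(N/C(=C/[N+](=O)[O-])N[C@@H](C)C(C)(C)C)c1`: not yet measured

Going by the values given here, in a functional assay for inhibition, with Rattus norvegicus as the target (on this read-out lower numbers stand for stronger inhibition and higher numbers for weaker inhibition), compound 2 gives 1580 nM, its only number, beside one further entry without a single number. The entries for compound 1 lie far apart: the several entries of compound 1 in this assay, 10 nM; 1000 nM (2 entries). The change to compound 3 is purely one of configuration: the two compounds have the same atoms and bonds and differ only in configuration as drawn: 1 of 2 stereo elements differ; a stereocentre at a saturated chain carbon is drawn R in compound 2 and S in compound 3. Among the compounds with values here, no measured pair shows what such an inversion does, so the size is a judgement. The expected change is a 2.5-fold higher number from compound 2 to compound 3 (0.40 log units; beyond the scatter), towards weaker inhibition and modestly beyond the scatter. The estimate for compound 3 is 4000 nM, with an expected range of 1000 nM to 20000 nM.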

Compound 3, half-maximal inhibitory concentration: 15.9 nM
For compound 3 the middle estimate is 250-fold (2.40 log units) above the measured one; the measured number lies below the stated range.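

In this assay, the chain stereocentre turns out to be a decisive position in this series, with a 99-fold lower number from compound 2 to compound 3 (2.00 log units; beyond the scatter). The S form at the saturated chain carbon gives the stronger inhibition of this pair, and no other structural change contributes to the step: the fact that compounds 2 and 3 differ only in the configuration as drawn.

On these data alone, whether the inversion has a similar size with an ethoxy group or a nitrile in place of the methoxy group remains open. The entries for compound 1 provide no single reference value: the several entries of compound 1 in this assay, 10 nM; 1000 nM (2 entries).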